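The source may hold more compounds than are shown below. What is called first, only, known or untested is meant among the compounds shown, and "the series" means these compounds.

Measured compounds:
compound 1, `COc1ccc(-c2nnc(SC/C(=N/O)c3ccccc3)n2-c2ccccc2)cc1`: 63%
compound 2, `C=CCn1c(SC/C(=N/O)c2ccccc2)nnc1-c1ccc(OC)cc1`: 67%
compound 3, `CCn1c(SC/C(=N/O)c2ccccc2)nnc1-c1ccc(OC)c(OC)c1`: 71%

In a functional assay on the whole organism (strain albino) for inhibition, with Rattus norvegicus as the target, read by paw edema, with a stated time of 3 h, at a dose of 0.28 mmol/kg by the oral route (on this read-out lower numbers stand for less inhibition and higher numbers for more inhibition at the one dose given (going by the name of the read-out)), the three compounds sit close together. Compound 3 gives 71%, and its gaps to compound 2 and to compound 1 both lie within the usual scatter of this assay, so none of the three can be set apart from the others.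

Compound 4, `CCn1c(SC/C(=N/O)c2ccccc2)nnc1-c1ccc(OC)cc1`, differs from compound 3 in one place: hydrogen in place of methoxy on an aromatic carbon. Among the measured compounds shown here, no measured pair shows this exact change. For the measured compounds named here, the only single-place step on record is a number 4 percentage points higher from compound 1 to compound 2 (within the scatter), which concerns the group on the aromatic nitrogen, not a methoxy group, and it stayed within the scatter. Going by the values given here, compound 2 and compound 3 differ in more than one place, so their values show only that a compound with one methoxy group and one with two gave numbers within the scatter of each other. Nothing on record points to a shift beyond the scatter, so for compound 4 a step of a number 4 percentage points lower from compound 3 to compound 4 (within the scatter) is expected, essentially none. Compound 4 is therefore estimated at 67%, within 55% to 79%.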

Compound 4, a percentage reported as inhibition, in the whole organism at one dose (the size of the read-out at that dose, not a potency): 75%
Compound 4: middle estimate off by 8 percentage points, on the low side, and the stated range covers the measured number.
By their numbers in this assay, from the lowest: compounds 1, 2, 3 and 4 (each within the scatter of the next, the first and the last beyond it).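

Hydrogen in place of methoxy on this aromatic carbon, ortho to a methoxy group, gives a number 4 percentage points higher from compound 3 to compound 4 (within the scatter) in this assay and is the first direct reading of this change, which shows that the two groups cannot be told apart here. Among the compounds shown here, on the aromatic nitrogen, ethyl set against allyl gives a number 8 percentage points higher from compound 2 to compound 4 (within the scatter) and so cannot be separated from it, while ethyl set against phenyl gives a number 12 percentage points higher from compound 1 to compound 4 (beyond the scatter) and is the first single-place step to clear the usual spread, though only modestly. Nothing measured here accounts for any of these steps.

Open, as far as these compounds go, is whether a hydroxyl group or a chlorine on that aromatic carbon would behave like hydrogen and methoxy. Also open, from the compounds shown here alone, is how a longer chain such as butyl on the aromatic nitrogen would compare with ethyl.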